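A few compounds are considered here, and "the series" means these few. Any claim that something is new, unique, unknown or untested is made for them only; others in the source may bear on it.

Compound 2 `O=C(N[C@H]1CN(S(=O)(=O)c2ccccc2)C[C@@H]1C(=O)N[C@H]1CCCNC1)c1nnc(-c2ccc(F)cc2)s1` gives 89% in a functional assay on HEK293 cells for agonist activity at growth hormone secretagogue receptor type 1 (Homo sapiens), read by HTRF and inositol phosphate accumulation, with a stated time of 90 min, in the presence of a further agent that is not named here (a higher number here means a larger maximal response, a lower number a smaller maximal response), the lower of the two numbers measured there, while compound 1 `Cc1ccc2[nH]c(C(=O)N[C@H]3CN(S(=O)(=O)c4ccccc4)C[C@@H]3C(=O)N[C@H]3CCCNC3)cc2c1` gives 98%. The step of a number 9 percentage points lower from compound 1 to compound 2 (within the scatter) exchanged one aromatic group on the carbonyl carbon for another without leaving the scatter. Compound 3 `O=C(N[C@H]1CN(S(=O)(=O)c2ccccc2)C[C@@H]1C(=O)N[C@H]1CCCNC1)c1cc(-c2ccccc2Cl)on1` differs from compound 2 by a group of 12 heavy atoms (9 carbon, 1 nitrogen, 1 oxygen, 1 chlorine; one five-membered aromatic ring with 2 hetero atoms, one six-membered aromatic ring of carbon only) in place of a group of 12 heavy atoms (8 carbon, 2 nitrogen, 1 fluorine, 1 sulfur; one five-membered aromatic ring with 3 hetero atoms, one six-membered aromatic ring of carbon only), on a carbonyl carbon. Among the measured compounds shown here, only that one step bears on this change, and it was small, so no shift beyond the scatter is expected in this assay. Compound 3 is therefore estimated at 90% (range 72% to 105%), a step of a number 1 percentage points higher from compound 2 to compound 3 (within the scatter) that is expected to stay within the scatter.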

Compound 3, largest response reached (Emax), in percent of the reference or control that the assay uses: 98%
Estimate against measurement, compound 3: 8 percentage points below; low and high end bracket the measured number.
By their numbers in this assay, from the lowest: compounds 2, 1 and 3 (each within the scatter of the next).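

With a further exchange of the group on the carbonyl carbon, this assay still stays within the scatter (a number 9 percentage points higher from compound 2 to compound 3 (within the scatter); no change at the digits printed from compound 1 to compound 3 (within the scatter)). Among these compounds, this position carries a five-membered aromatic ring with 1, 2 or 3 hetero atoms, and no step leaves the scatter. Nothing measured here accounts for this result. On these data alone, what stays open is whether the maximal response holds when a carboxylic acid, an amine or a plain methyl group stands on this carbonyl carbon in place of the two-ring groups.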